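This account rests on a few compounds, and the source may have more. Where it says the series, first, only, none or still open, it means among the compounds named here.

Measured compounds:
- compound 1 `COc1cccc(Nc2nc3cccc(-c4c(F)cccc4OC)c3o2)n1`: 620 nM
- compound 2 `COc1cc(Nc2nc3cccc(-c4c(F)cccc4OC)c3o2)cc(OC)c1`: 210 nM
- compound 3 `COc1ccccc1-c1cccc2nc(Nc3cc(OC)c(OC)c(OC)c3)oc12`: 20 nM

All three numbers come from an assay on isolated protein for inhibition of ribosomal protein S6 kinase alpha-2 (Homo sapiens), with a stated time of 150 min; a lower number here means a stronger inhibitor, a higher number a weaker inhibitor. Compound 3 stands lowest of the three. Its nearest neighbour is compound 2, whose number is higher by an amount beyond the scatter, and compound 1 lies further still. No two of the measured compounds differ in a single place, so none of these gaps can be tied to one structural change; compound 3 differs from compound 2 both in the aryl group carried on the core and in the pattern of methoxy groups on the aniline.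

Compound 4 `COc1cc(Nc2nc3cccc(-c4c(F)cccc4OC(C)C)c3o2)cc(OC)c1OC` has not yet been measured in this assay. Relative to compound 3 the change is a group of 11 heavy atoms (9 carbon, 1 oxygen, 1 fluorine; one six-membered aromatic ring of carbon only) in place of a group of 8 heavy atoms (7 carbon, 1 oxygen; one six-membered aromatic ring of carbon only), on an aromatic carbon. The aniline part of compound 4 is the same as in compound 3. The entering group resembles the aryl group carried by compound 1 and compound 2, save that the isopropoxy replaces a methoxy; those two compounds give the higher numbers of the set, but they carry different anilines, so no direct reading follows.

Expected step: from compound 3 to compound 4, a change no larger than the scatter, or a modest rise, is estimated, a 1.8-fold higher number from compound 3 to compound 4 (0.24 log units; within the scatter). Compound 4 is estimated at 35 nM (range 12 nM to 120 nM).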

Compound 4, half-maximal inhibitory concentration: 970 nM
Compound 4: middle estimate off by 28-fold (1.44 log units), on the low side, and the stated range ends below it.
By their numbers in this assay, from the lowest: compound 3; then compound 2; then compounds 1 and 4 (each within the scatter of the next).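

In this assay, among the compounds shown here, with the aniline part held constant, placing the larger fluorinated, isopropoxy-bearing aryl group on this aromatic carbon in place of 2-methoxyphenyl gives a 49-fold higher number from compound 3 to compound 4 (1.69 log units; beyond the scatter), the first step that can be tied to one place on the core. The aniline part shared by compound 3 and compound 4 is therefore not enough on its own to keep the number low, and the group on this aromatic carbon can move the read-out by a large amount. Nothing measured on these compounds bears on the origin of the step, which adds the fluorine and replaces methoxy with isopropoxy in a single change.

The compounds shown leave open how the step divides between these two differences, since neither an isopropoxyphenyl group without the fluorine nor the fluorinated methoxyphenyl group of compound 1 and compound 2 appears on the aniline part of compound 3. They also leave open how an ethoxy group or an unsubstituted phenyl group at this position would read in this assay.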